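The source may hold more compounds than are shown below. What is called first, only, known or untested is meant among the compounds shown, and "the series" means these compounds.

Measured so far in a functional assay on A-375 cells (Homo sapiens) for antiproliferative activity; on this read-out lower numbers stand for stronger inhibition and higher numbers for weaker inhibition:

- compound 1 `O=C(Nc1ccc(-c2ccn[nH]2)cc1)C1CCCN(Cc2ccc(F)c(F)c2)C1`: 520 nM
- compound 2 `O=C(Nc1ccc(-c2ccoc2)cc1)C1CCCN(Cc2ccc(F)c(F)c2)C1`: 1290 nM

Of these two compounds, compound 2 has the higher number, at 1290 nM, and so shows the weaker inhibition in this assay. Its nearest neighbour on the scale is compound 1, at 520 nM, and the gap between them lies beyond the scatter.

The next compound, compound 3 `O=C(Nc1ccc(-c2cccs2)cc1)C1CCCN(Cc2ccc(F)c(F)c2)C1`, has thiophen-2-yl in place of furan-3-yl on an aromatic carbon. The rest of the structure stays as it is in compound 2.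

Among the compounds with values here, only one measured step bears on this exchange, and it is indirect. Putting furan-3-yl in place of 1H-pyrazol-5-yl gave a 2.5-fold higher number from compound 1 to compound 2 (0.39 log units; beyond the scatter), which is a modest step. Within the data shown here, no measurement yet compares thiophen-2-yl with any other ring here. As that modest step is the largest guide available, and the counts for the leaving and entering rings match, no step beyond the scatter is expected. The expected step is a 1.1-fold lower number from compound 2 to compound 3 (0.03 log units; within the scatter).

For compound 3 the estimated value is 1200 nM, with an expected range from 500 nM to 3000 nM.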

Compound 3, half-maximal inhibitory concentration: 390 nM
The estimate for compound 3 lay 3.1-fold (0.49 log units) above the measured number, outside the stated range (below it).
By their numbers in this assay, from the lowest: compounds 3 and 1 (each within the scatter of the next); then compound 2.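

The exchange at this position, on an aromatic carbon of a six-membered aromatic ring of carbon only and para to a large group, shows that this assay can separate two rings that match in every count of heavy atoms, hetero atoms, hydrogen-bond donors and acceptors: there is a 3.3-fold lower number from compound 2 to compound 3 (0.52 log units; beyond the scatter). The result also changes the reading of the earlier pyrazole-to-furan step, since with a 1.3-fold lower number from compound 1 to compound 3 (0.12 log units; within the scatter), thiophen-2-yl and 1H-pyrazol-5-yl cannot be told apart here, and of these three rings only furan-3-yl stands beyond the scatter from both others. No measurement shown accounts for the gap between the two rings with matching counts.

The exchange alters both the hetero atom and the point of attachment, so the compounds shown leave open which of the two goes with the step, a question that furan-2-yl or thiophen-3-yl at this position would address. They also leave open how a six-membered ring such as pyridine, or a simple phenyl group, would compare with these five-membered rings.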